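The source may hold more compounds than are shown below. What is called first, only, known or untested is meant among the compounds shown, and "the series" means these compounds.

Compound 1 `CCCCCCCCCCCCCCNC(=O)[C@H](CO)/N=C/c1ccc([N+](=O)[O-])cc1` is a long-chain amide of serine carrying an imine to a nitroaryl group. In a functional assay on cells (Homo sapiens) for cytotoxicity, read by MTT assay, with a stated time of 24 h (a lower number here means a stronger inhibitor, a higher number a weaker inhibitor), compound 1 gives 217000 nM, which is the highest number among the three measured compounds. Compound 3 `CCCCCCCCCCCCCCNC(=O)[C@H](CO)/N=C/c1cccc([N+](=O)[O-])c1` gives 104000 nM in this assay, and compound 2 `CCCCCCCCCCCCCCNC(=O)[C@H](CO)NCc1ccccc1OC`, where the imine has been reduced to an amine and the aryl group carries a methoxy, gives 100000 nM in this assay. Within the data shown here, the only single-point step that has been measured runs from compound 1 to compound 3, with a 2.1-fold lower number from compound 1 to compound 3 (0.32 log units; beyond the scatter).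

Compound 4 `CCCCCCCCCCCCCCNC(=O)[C@H](CO)/N=C/c1cccc(O)c1` differs from compound 1 in one place: 3-hydroxyphenyl in place of 4-nitrophenyl on a carbon with a double bond to nitrogen. The measured step from compound 1 to compound 3 bears on this change in part, since both move the substituent from the 4-position to the 3-position of the phenyl ring; what the exchange of nitro for hydroxyl does on its own has not been measured in this series. Given that, compound 4 is expected to show a modest step toward a lower number in this assay, of about a 1.8-fold lower number from compound 1 to compound 4 (0.26 log units; within the scatter), with the range widened for the untested swap of groups. The estimate for compound 4 in this assay is therefore 120000 nM, between 50000 nM and 300000 nM.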

Compound 4, half-maximal inhibitory concentration: 32600 nM
Estimate against measurement, compound 4: 3.7-fold (0.57 log units) above; measured number outside the range, below it.
By their numbers in this assay, from the lowest: compound 4; then compounds 2 and 3 (each within the scatter of the next); then compound 1.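

Among these compounds, with the substituent held at the same ring position, hydroxy in place of nitro on an aromatic carbon gives a 3.2-fold lower number from compound 3 to compound 4 (0.50 log units; beyond the scatter) in this assay and so shows for the first time that the identity of this group, and not only where it sits, moves the number beyond the scatter. The full exchange of 4-nitrophenyl for 3-hydroxyphenyl gives a 6.7-fold lower number from compound 1 to compound 4 (0.82 log units; beyond the scatter) and exceeds the earlier 2.1-fold lower number from compound 1 to compound 3 (0.32 log units; beyond the scatter) between the two nitrophenyl isomers, while the listed step to the reduced compound carrying the methoxy aryl group, a 3.1-fold lower number from compound 2 to compound 4 (0.49 log units; beyond the scatter) in the same assay, changes the link and the aryl group together and cannot separate the two. No measurement given here accounts for why the hydroxy compound gives the lowest number.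

The compounds shown leave open whether 4-hydroxyphenyl would give a similar number to 3-hydroxyphenyl, and whether an amine or a carboxylic acid in place of the hydroxy would hold the gain. They also leave open how a shorter chain on the amide, or a reduced amine link bearing the 3-hydroxyphenyl group, would behave.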